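The source may hold more compounds than are shown below. What is called first, only, known or untested is meant among the compounds shown, and "the series" means these compounds.

Compound 3 `O=C1O[C@]2(CC[C@H](CNc3cnn(-c4ccccc4F)c3)CC2)CN1c1cncnc1` is the strongest of the three measured compounds in a functional assay for antagonist activity at Neuropeptide Y receptor type 5 (Homo sapiens); a higher number here means a weaker inhibitor, a lower number a stronger inhibitor: compound 3 gives 0.0398 nM. Compound 2 `O=C1O[C@]2(CC[C@H](CNc3ccc(-c4ncccn4)cn3)CC2)CN1c1ccccn1` gives 0.159 nM, and compound 1 `Cc1ncccc1N1C[C@]2(CC[C@@H](CNc3cnn(-c4ccccc4F)c3)CC2)OC1=O` gives 0.631 nM. Compound 4 `O=C1O[C@]2(CC[C@H](CNc3cnn(-c4ccccc4F)c3)CC2)CN1c1cccnc1` has not yet been measured; it differs from compound 3 in one place, (pyridin-3-yl in place of pyrimidin-5-yl on an amide-type nitrogen in a ring).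

Going by the values given here, only one measured step bears on this change, and it touches the same position: a 16-fold lower number from compound 1 to compound 3 (1.20 log units; beyond the scatter). That step exchanges a 2-methylpyridin-3-yl for the pyrimidin-5-yl and is large. Compound 4 carries a pyridin-3-yl, which lies between those two groups in what it has, so a step back in the direction of compound 1 is expected, but not all the way, since compound 1 also carries a methyl group that compound 4 lacks. Compound 4 is therefore expected to be somewhat weaker than compound 3. The expected step is a 2.5-fold higher number from compound 3 to compound 4 (0.40 log units; beyond the scatter), estimated to be clearly smaller than the large step just described. Compound 4 is estimated at 0.1 nM, in the range 0.03 nM to 0.4 nM.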

Compound 4, inhibition constant: 0.1 nM
Beside the measured number, compound 4's estimate shows no gap at the digits printed; low and high end bracket the measured number.
By their numbers in this assay, from the lowest: compound 3; then compounds 4 and 2 (each within the scatter of the next); then compound 1.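

Read in this assay at the position on an amide-type nitrogen in a ring, the loss of one ring nitrogen has a cost beyond the scatter when pyridin-3-yl replaces pyrimidin-5-yl (a 2.5-fold higher number from compound 3 to compound 4 (0.40 log units; beyond the scatter)). The methyl group also matters on its own, since hydrogen in place of methyl on an aromatic carbon gives a further change (a 6.3-fold lower number from compound 1 to compound 4 (0.80 log units; beyond the scatter)), so the large step (a 16-fold lower number from compound 1 to compound 3 (1.20 log units; beyond the scatter)) is now seen to combine two separate modest changes. Nothing at hand explains why either change acts as it does.

The compounds shown leave open whether a methyl group would have a similar effect on the pyrimidin-5-yl ring of compound 3. They also leave open how a plain phenyl ring or a methoxy-bearing pyridine would compare on this nitrogen.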